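The source may report more compounds than this note shows. Statements on the series, on what has been measured and on what is new or still open speak of the compounds shown alone.

Working notes on the series.

Compound 1 `NC1=NC2(CCOCC2)N(OCCCOc2ccccc2)C(N)=N1` is the reference of this set. In an assay on isolated protein for inhibition of Dihydrofolate reductase (Homo sapiens), read by spectrophotometry, using NADPH, with stated times of 5 s and 6 min, tested at 5 uM (a lower number here means a weaker effect, a higher number a stronger effect of the compound at the concentration tested), compound 1 gives > 90%, which is a limit of the assay and not a number. Compound 2 `Cc1cc(C)cc(OCCCON2C(N)=NC(N)=NC23CCOCC3)c1` gives 84.3% in this assay. Compound 3 `NC1=NC2(CCSCC2)N(OCCCOc2ccccc2Br)C(N)=N1`, which carries both a sulfur-containing core and a bromine on the phenoxy ring, gives 88.7% in this assay. Within the data shown here, the single measured step, a number at least 5.7 percentage points lower from compound 1 to compound 2 (that floor lies within the scatter), is the only step between neighbours, and it starts from a limit, as the limit of > 90% in this assay, at which 1 of the 3 values shown sits, records. Compound 3 differs from compound 1 in two places, so its value is noted alone; it shows that a brominated phenoxy ring remains compatible with strong inhibition at this concentration.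

Compound 4 `NC1=NC2(CCOCC2)N(OCCCOc2cccc(Br)c2)C(N)=N1` differs from compound 1 by bromo in place of hydrogen on an aromatic carbon. Among the measured compounds shown here, no measured step isolates this change. Compound 1 sits at a limit in this assay. Compound 3 gives 88.7% in this assay, and on that basis compound 4 is expected to stay near the top of the range, with a number no higher from compound 1 to compound 4 (the limit leaves the size open) expected to lie within the scatter. Compound 4 is therefore estimated at 90% in this assay, between 82% and 97%.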

Compound 4, a percentage reported as inhibition, at one concentration (the size of the read-out at that concentration, not a potency): 86.7%
The estimate for compound 4 lay 3.3 percentage points above the measured number; the measured number falls inside the stated range.
By their numbers in this assay, from the lowest: compounds 2, 4 and 3 (each within the scatter of the next). At a limit, above all of these: compound 1.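

Compound 4 is the only compound shown in which bromo is added to the phenoxy ring with nothing else changed, whereas compound 3 also differs from compound 1 in its core; the step is a number at least 3.3 percentage points lower from compound 1 to compound 4 (that floor lies within the scatter). Going by these compounds, the size of this step stays open because compound 1 sits at a limit of the assay, not at a number: the limit of > 90% in this assay, at which 1 of the 4 values shown sits. Against the dimethyl-substituted ring the step is a number 2.4 percentage points higher from compound 2 to compound 4 (within the scatter), so 3-bromophenyl and 3,5-dimethylphenyl are not told apart at this concentration.

On these data alone, whether an amine or a carboxylic acid in place of bromo on this aromatic carbon would keep the inhibition remains open. A percentage at one concentration is not a potency, so any difference in potency among these compounds also remains open.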